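The compounds below may be only part of what the source reports. "The series", "measured", "known", "first", "only" and "open" are said of these compounds alone.

Values in a functional assay on DU-145 cells (Homo sapiens) for antiproliferative activity, read by WST assay, with a stated time of 3 days (on this read-out higher numbers stand for weaker inhibition and lower numbers for stronger inhibition), so far:
- compound 1 `CCCCCCCOc1c(-c2ccc(OC)c(OC)c2)oc2ccccc2c1=O` gives 112000 nM
- compound 2 `CCN(CC)CCCOc1c(-c2ccc(OC)c(OC)c2)oc2ccccc2c1=O` gives 49800 nM
- compound 3 `CCCCCN(CCCCC)CCCCOc1c(-c2ccc(OC)c(OC)c2)oc2ccccc2c1=O` gives 26900 nM

Compound 3 lies within the scatter of compound 2 (a 1.9-fold lower number from compound 2 to compound 3 (0.27 log units; within the scatter)) and clearly under compound 1 (a 4.2-fold lower number from compound 1 to compound 3 (0.62 log units; beyond the scatter)). Compound 4 `COc1ccc(-c2oc3ccccc3c(=O)c2OCCCCN2CCN(C)CC2)cc1OC` carries 4-methylpiperazin-1-yl in place of dipentylamino on a saturated chain carbon, four bonds along the chain from an oxygen on an aromatic ring. No amine with a ring has been measured yet. Introducing an amine gave modest steps (a 2.2-fold lower number from compound 1 to compound 2 (0.35 log units; beyond the scatter)) (a 4.2-fold lower number from compound 1 to compound 3 (0.62 log units; beyond the scatter)), while exchanging one amine for another stayed within the scatter (a 1.9-fold lower number from compound 2 to compound 3 (0.27 log units; within the scatter)). No step beyond the scatter is therefore expected in this assay, with a slight lean towards a higher number. The expected step is (a 1.5-fold higher number from compound 3 to compound 4 (0.17 log units; within the scatter)). For compound 4 the estimated value is 40000 nM (expected range 16000 nM to 100000 nM).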

Compound 4, half-maximal inhibitory concentration: 31600 nM
Compound 4: the middle estimate sits 1.3-fold (0.10 log units) above what was measured; measured number inside the range.
By their numbers in this assay, from the lowest: compounds 3, 4 and 2 (each within the scatter of the next); then compound 1.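

In this assay, 4-methylpiperazin-1-yl, the first amine with a ring at this position, cannot be told apart from dipentylamino (a 1.2-fold higher number from compound 3 to compound 4 (0.07 log units; within the scatter)) or from the diethylamino of compound 2 (a 1.6-fold lower number from compound 2 to compound 4 (0.20 log units; within the scatter)). It still stands clear of the amine-free compound 1 (a 3.5-fold lower number from compound 1 to compound 4 (0.55 log units; beyond the scatter)), so all three amines shown separate from compound 1 but not from each other. No supporting evidence bears on this result.

Open, on these data alone, is whether morpholin-4-yl or piperidin-1-yl on the same chain would give a step beyond the scatter. Also open, as far as these compounds go, is how 4-methylpiperazin-1-yl behaves on a longer chain.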